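Trimming the benzyloxy tail to methoxy on a shared core

This account rests on a few compounds, and the source may have more. Where it says the series, first, only, none or still open, it means among the compounds named here.

Measured so far:
compound 1, `O=C1NCc2c1c1c(c3c2c2ccccc2n3CCO)CCc2cc(OC3CCCCC3)ccc2-1`, 35%
compound 2, `O=C1NCc2c1c1c(c3c2c2ccccc2n3CCO)CCc2cc(OCCOCc3ccccc3)ccc2-1`, 9%

Two compounds share one core and differ only in the group on an oxygen on an aromatic ring. In an assay on isolated protein for inhibition of mitogen-activated protein kinase kinase kinase 9 (Homo sapiens), tested at 1 uM (on this read-out higher numbers stand for more inhibition at the one concentration tested (going by the name of the read-out) and lower numbers for less inhibition), compound 1 gives 35%, while compound 2 gives 9%, the lowest of the two numbers. Among the compounds with values here, the one measured step, a number 26 percentage points lower from compound 1 to compound 2 (beyond the scatter), goes with 2-(benzyloxy)ethyl in place of cyclohexyl.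

Compound 3, `COCCOc1ccc2c(c1)CCc1c-2c2c(c3c4ccccc4n(CCO)c13)CNC2=O`, is not yet measured. It differs from compound 2 by hydrogen in place of phenyl on a saturated chain carbon bound to an oxygen on a saturated carbon, so the 2-(benzyloxy)ethyl of compound 2 becomes 2-methoxyethyl. Within the data shown here, no measured step removes a phenyl on its own; the step from compound 1 to compound 2 exchanged the whole group on the oxygen, so it bears on this change only indirectly, showing that this position is sensitive but not in which direction a shorter chain moves the read-out. Compound 2 already sits low, which leaves more room upward than downward. Compound 3 is therefore expected near 14%, between 0% and 38%, a step of a number 5 percentage points higher from compound 2 to compound 3 (within the scatter) that is expected to stay within the scatter.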

Compound 3, a percentage reported as inhibition, at one concentration (the size of the read-out at that concentration, not a potency): 52%
Compound 3: middle estimate off by 38 percentage points, on the low side; measured number above the stated range.
By their numbers in this assay, from the lowest: compound 2; then compound 1; then compound 3.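

In this assay, losing only the phenyl, so that 2-(benzyloxy)ethyl becomes 2-methoxyethyl, gives a number 43 percentage points higher from compound 2 to compound 3 (beyond the scatter) and supplies what the first pair could not: the direction of a change within this group on the oxygen. The low number of compound 2 therefore goes with the phenyl on the saturated chain carbon, since the 2-methoxyethyl chain without it reads high, and a chain on this oxygen does not in itself go with a low number. The exchange of the whole group gives a number 17 percentage points higher from compound 1 to compound 3 (beyond the scatter) and so places 2-methoxyethyl ahead of cyclohexyl on this read-out, although nothing available gives a reason for either step.

The compounds shown leave open how much the chain's inner oxygen and its length contribute, which a butyl group, a 3-methoxypropyl group or a 2-aminoethyl group on the same oxygen would begin to separate. They also leave open how these compounds rank by potency, as all three numbers come from a single concentration.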